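The compounds below may be only part of what the source reports. "The series", "measured", "known", "first", "only" and "open" are said of these compounds alone.

Measured so far in an assay for binding affinity to dual specificity mitogen-activated protein kinase kinase 4 (Homo sapiens), read by KINOMEscan, tested at 100 nM; on this read-out lower numbers stand for a stronger effect and higher numbers for a weaker effect at the one concentration tested:
compound 1 `CCCS(=O)(=O)Nc1ccc(F)c(C(=O)c2n[nH]c3ncc(-c4cccc(Cl)c4)cc23)c1F` gives 40%
compound 2 `CCCS(=O)(=O)Nc1ccc(F)c(C(=O)c2n[nH]c3ncc(-c4cccc(O)c4)cc23)c1F` gives 2.2%
compound 3 `CCCS(=O)(=O)Nc1ccc(F)c(C(=O)c2n[nH]c3ncc(-c4ccc(C)c(C)c4)cc23)c1F` gives 20%

Compound 2 stands lowest of the three numbers; the nearer value is that of compound 3, the furthest that of compound 1. The two steps connecting them: a number 17.8 percentage points higher from compound 2 to compound 3 (beyond the scatter); a number 37.8 percentage points lower from compound 1 to compound 2 (beyond the scatter).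

Compound 4 `CCCS(=O)(=O)Nc1ccc(F)c(C(=O)c2n[nH]c3ncc(-c4ccc(C(C)C)cc4)cc23)c1F` is not yet measured. It differs from compound 2 as follows: 4-isopropylphenyl in place of 3-hydroxyphenyl on an aromatic carbon. Both measured steps bear on this change, since each exchanges the 3-hydroxyphenyl for a group without donor or acceptor and each moves the number upward from the value of compound 2, one modestly, one largely. A rise beyond the scatter in this assay is therefore expected for compound 4, of a size between those two steps. The expected step is a number 27.8 percentage points higher from compound 2 to compound 4 (beyond the scatter). Compound 4 is estimated at 30%, with a range of 10% to 60%.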

Compound 4, a percentage reported as activity, at one concentration (the size of the read-out at that concentration, not a potency): 17%
For compound 4 the middle estimate is 13 percentage points above the measured one; low and high end bracket the measured number.
By their numbers in this assay, from the lowest: compound 2; then compounds 4 and 3 (each within the scatter of the next); then compound 1.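

In this assay, 4-isopropylphenyl, a second alkyl-substituted phenyl with no donor or acceptor, also fails to match 3-hydroxyphenyl, giving a number 14.8 percentage points higher from compound 2 to compound 4 (beyond the scatter). It cannot be told apart from 3,4-dimethylphenyl, giving a number 3 percentage points lower from compound 3 to compound 4 (within the scatter), whereas the step from 3-chlorophenyl gives a number 23 percentage points lower from compound 1 to compound 4 (beyond the scatter), so the two alkyl-substituted phenyl groups sit together, apart from the chloro group. Nothing measured here explains these differences. Open, going by these compounds, is whether the hydroxy group needs the place it holds in compound 2, and whether 4-hydroxyphenyl or 3-aminophenyl would match compound 2.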